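The source may hold more compounds than are shown below. What is called first, only, known or untested is meant among the compounds shown, and "the series" means these compounds.

Measured so far in an ADME assay on the whole organism (Rattus norvegicus) for pharmacokinetics, at a dose of 5 mg/kg by the oral route; a lower number here means that a smaller share of the oral dose reaches the circulation, a higher number that a larger share of the oral dose reaches the circulation:
- compound 1 `COc1cnc(O[C@@H]2C[C@H]3C(=O)N[C@]4(C(=O)NS(=O)(=O)C5(C)CC5)C[C@H]4/C=C\CC[C@@H](C)C[C@@H](C)[C@H](NC(=O)OC(C)(C)C(F)(F)F)C(=O)N3C2)c2ccccc12`: 60%
- compound 2 `CC[C@@H]1C[C@H](C)CC/C=C\[C@@H]2C[C@@]2(C(=O)NS(=O)(=O)C2CC2)NC(=O)[C@@H]2C[C@@H](Oc3ncc(OC)c4ccccc34)CN2C(=O)[C@H]1NC(=O)OC(C)(C)C(F)(F)F`: 61%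
- compound 3 `CC[C@@H]1C[C@H](C)CC/C=C\[C@@H]2C[C@@]2(C(=O)NS(=O)(=O)C2(C)CC2)NC(=O)[C@@H]2C[C@@H](Oc3ncc(OC)c4ccccc34)CN2C(=O)[C@H]1NC(=O)OC(C)(C)C(F)(F)F`: 42%

Of these three, compound 3 has the lowest number, at 42%. The other two compounds both lie clearly higher, as the data show a number 18 percentage points lower from compound 1 to compound 3 (beyond the scatter) and a number 19 percentage points lower from compound 2 to compound 3 (beyond the scatter). Each of these steps adds a methyl in place of hydrogen on a saturated carbon, so together they show that single-atom-sized edits in this series can move this assay by a modest amount.

Compound 4 `CC[C@@H]1C[C@H](C)CC/C=C\[C@@H]2C[C@@]2(C(=O)NS(=O)(=O)C2(C)CC2)NC(=O)[C@@H]2C[C@@H](Oc3ncc(OC)c4ccc(F)cc34)CN2C(=O)[C@H]1NC(=O)OC(C)(C)C(F)(F)F` keeps all of compound 3 except for one change, fluoro in place of hydrogen on an aromatic carbon. Within the data shown here, no measured step touches that aromatic ring, and none involves fluoro. The two methyl steps therefore offer only a rough scale for how far a small edit may reach, and they give no direction for this one. With no evidence pointing either way, no shift beyond the scatter is expected, though a modest one cannot be ruled out. The expected step is a number 1 percentage points lower from compound 3 to compound 4 (within the scatter), an estimate that stays close to no change. Compound 4 is therefore expected at 41%, with an estimated range from 24% to 58%.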

Compound 4, oral bioavailability: 47%
Estimate against measurement, compound 4: 6 percentage points below; the range from low to high includes it.
By their numbers in this assay, from the lowest: compounds 3 and 4 (each within the scatter of the next); then compounds 1 and 2 (each within the scatter of the next).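

Among these compounds, compound 4 is the first compound here with a change on the six-membered aromatic ring of carbon only, and in this assay this change gives a number 5 percentage points higher from compound 3 to compound 4 (within the scatter); at this carbon, meta to a fused ring and para to a fused ring, fluoro can thus take the place of hydrogen without a shift that stands out from repeated measurements. The two earlier steps, each a methyl in place of hydrogen on a saturated carbon, had both moved the number beyond the scatter, so the series now also holds a small edit that does not, and the sensitivity seen at those saturated carbons does not extend to fluoro at this aromatic carbon. No independent measurement is available to explain this outcome.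

The compounds shown leave open whether chloro, a nitrile or an amine on this same carbon would also stay within the scatter of compound 3 in this assay. They also leave open whether fluoro on another carbon of this ring, or the same fluoro on the core of compound 1 or compound 2, would give a similar result.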